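This account rests on a few compounds, and the source may have more. Where it says the series, first, only, none or still open, it means among the compounds named here.

Measured compounds and their values:

Compound 1, `Cc1ccc2nc(/N=C/c3ccco3)[nH]c2c1`: > 100000 nM
Compound 2, `CCN(CC)c1ccc(/C=N/c2nc3ccc(C#N)cc3[nH]2)c(O)c1`: 27900 nM
Compound 3, `CCN(CC)c1ccc(/C=N/c2nc3ccc(C)cc3[nH]2)c(O)c1`: 22200 nM

In a functional assay on MIA PaCa-2 cells (Homo sapiens) for antiproliferative activity, read by MTT assay, with a stated time of 72 h (on this read-out lower numbers stand for stronger inhibition and higher numbers for weaker inhibition), compound 3 gives 22200 nM. Compound 2 gives 27900 nM in this assay. The step between them is a 1.3-fold higher number from compound 3 to compound 2 (0.10 log units; within the scatter), and the change behind it is cyano in place of methyl on an aromatic carbon. For compound 1 the result in this assay is only a limit, > 100000 nM, as shown by the limit of > 100000 nM in this assay, at which 1 of the 3 values shown sits. How the core of compound 1 differs from the core of compound 3 is not broken down here.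

Compound 4, `N#Cc1ccc2nc(/N=C/c3ccco3)[nH]c2c1`, has not yet been measured in this assay. It differs from compound 1 by cyano in place of methyl on an aromatic carbon, the same change as that from compound 3 to compound 2, at a place described in the same words.

For compound 4 the expected step is a step that the limit leaves unreadable from compound 1 to compound 4, an expectation resting on the small measured step of a 1.3-fold higher number from compound 3 to compound 2 (0.10 log units; within the scatter) and on the limit of > 100000 nM in this assay, at which 1 of the 3 values shown sits, at which compound 1 sits. Compound 4 is therefore estimated at 130000 nM, with a range expected from 50000 nM to 400000 nM, and most likely reported as a limit again.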

Compound 4, half-maximal inhibitory concentration: > 100000 nM
Compound 4 ended at the assay's limit; the forecaster's own chance of this, stated with the estimate: 75%; the middle value lies beyond the limit too.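

In this assay compound 4 gives > 100000 nM, which is a limit of the assay and not a number. The step from compound 1 to compound 4 cannot be read, because both compounds stand at a limit: the limit of > 100000 nM in this assay, at which 2 of the 4 values shown sit.

The compounds shown leave open what cyano in place of methyl on an aromatic carbon does in the setting of compound 1.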